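Compound 3: hydrogen in place of fluoro

The compounds below may be only part of what the source reports. "The series", "measured", "known", "first", "only" and "open" are said of these compounds alone.

In an ADME assay on microsomes from liver (Canis lupus familiaris) for metabolic stability, read by LC-MS, using NADPH, with a stated time of 30 min, tested at 1 uM (a higher number here means that more of the compound is left, a lower number that less of the compound is left), compound 1 (`C=CC(=O)Nc1cc(Nc2ncc(I)c(Nc3ccccc3S(=O)(=O)N(C)C)n2)c(OC)cc1N(C)CCN(C)C`) gives 35% and compound 2 (`C=CC(=O)Nc1cc(Nc2ncc(F)c(Nc3ccccc3S(=O)(=O)N(C)C)n2)c(OC)cc1N(C)CCN(C)C`) gives 33%. These two numbers lie within the scatter of each other, so compound 2 stands level with compound 1 in this pair.

The next structure is compound 3 (`C=CC(=O)Nc1cc(Nc2nccc(Nc3ccccc3S(=O)(=O)N(C)C)n2)c(OC)cc1N(C)CCN(C)C`), with hydrogen in place of fluoro on an aromatic carbon. Among the compounds with values here, the only measured step at this place is a number 2 percentage points lower from compound 1 to compound 2 (within the scatter), for fluoro in place of iodo on the same aromatic carbon. Within the data shown here, no measured step yet involves hydrogen there, so this one step is thin support. On that evidence, no step beyond the scatter is expected in this assay. The expected step is a number 1 percentage points higher from compound 2 to compound 3 (within the scatter). Compound 3 is estimated at 34%, with an expected range of 21% to 48%.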

Compound 3, percent of the compound remaining: 50%
Estimate against measurement, compound 3: 16 percentage points below; measured number outside the range, above it.
By their numbers in this assay, from the lowest: compounds 2 and 1 (each within the scatter of the next); then compound 3.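

In this assay the group on this aromatic carbon does affect the read-out, but the divide shown lies between hydrogen and the two halogens: removing fluoro gives a number 17 percentage points higher from compound 2 to compound 3 (beyond the scatter) and removing iodo gives a number 15 percentage points higher from compound 1 to compound 3 (beyond the scatter), while the exchange of one halogen for the other gave only a number 2 percentage points lower from compound 1 to compound 2 (within the scatter) here. Across these three compounds, hydrogen therefore stands apart from both fluoro and iodo, with no compound going against that reading. No measured data at hand explain this difference.

Still open, from the compounds shown here alone, is whether hydrogen alone gives this higher number, or whether a methyl group, a nitrile or an amine on the same carbon would do the same. Going by these compounds, it is also open whether the step holds when the dimethylsulfonamide group is replaced by another group.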